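This account rests on a few compounds, and the source may have more. Where it says the series, first, only, none or still open, it means among the compounds named here.

Within the data shown here, compound 2 `O=S(=O)(NCCCNc1nccc(-c2c(-c3cccc(F)c3)nc3sccn23)n1)c1ccccc1` is the lower of the two compounds measured so far in a functional assay on A-375 cells (Homo sapiens) for cytotoxicity, read by MTT assay; on this read-out lower numbers stand for stronger inhibition and higher numbers for weaker inhibition. In this assay, among the measured compounds shown here, compound 2 gives 6600 nM, while compound 1 `Cc1ccc(S(=O)(=O)NCCNc2nccc(-c3c(-c4cccc(F)c4)nc4sccn34)n2)cc1` gives 15400 nM; the step of a 2.3-fold lower number from compound 1 to compound 2 (0.37 log units; beyond the scatter) is the only measured step available, and it changed the sulfonamide group and the chain length together, so its two parts cannot be separated on these numbers.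

Compound 3 `Cc1ccc(C(=O)NCCNc2nccc(-c3c(-c4cccc(F)c4)nc4sccn34)n2)cc1` differs from compound 2 by ((4-methylphenyl)carbonyl)amino in place of ((phenylsulfonyl)amino)methyl on a saturated chain carbon, two bonds along the chain from a nitrogen on an aromatic ring. This change reverses the chain shortening of the measured step and returns the methylated aryl cap, while exchanging the sulfonyl for a carbonyl; in that sense compound 3 stands closer to compound 1 than to compound 2, apart from the carbonyl. For the measured compounds named here, no measured step addresses the sulfonyl-to-carbonyl exchange on its own.

Given that compound 1 gives 15400 nM and that the measured step went the other way, compound 3 is expected to give a higher number than compound 2 in this assay, a step of about a 1.8-fold higher number from compound 2 to compound 3 (0.26 log units; within the scatter). The estimate for compound 3 in this assay is 12000 nM, with a range from 3500 nM to 40000 nM.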

Compound 3, half-maximal inhibitory concentration: 5880 nM
Compound 3: middle estimate off by 2.0-fold (0.31 log units), on the high side; measured number inside the range.
By their numbers in this assay, from the lowest: compounds 3 and 2 (each within the scatter of the next); then compound 1.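

In this assay, the exchange of (4-methylphenyl)sulfonyl for (4-methylphenyl)carbonyl on an amine nitrogen can now be read on its own, and it gives a 2.6-fold lower number from compound 1 to compound 3 (0.42 log units; beyond the scatter) with nothing else in the structure altered. The larger replacement on the saturated chain carbon, ((4-methylphenyl)carbonyl)amino in place of ((phenylsulfonyl)amino)methyl, gives a 1.1-fold lower number from compound 2 to compound 3 (0.05 log units; within the scatter), so these two different groups cannot be told apart at this place on this read-out, even though they differ in heavy atoms and hydrogen-bond acceptors. No supporting data accompany these numbers that could explain either result.

The compounds shown still leave the separate contributions of the methyl on the aryl cap and of the chain length unresolved, as no single step isolates either one. On these data alone, whether a longer chain carrying the (4-methylphenyl)carbonyl group, or a urea in place of the carbonyl, would shift the number in this assay also remains open.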